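The source may report more compounds than this note shows. Statements on the series, on what has been measured and on what is new or still open speak of the compounds shown alone.

Measured so far in a functional assay on HEY cells (Homo sapiens) for cytotoxicity, read by MTT assay, with a stated time of 72 h; on this read-out higher numbers stand for weaker inhibition and lower numbers for stronger inhibition:
- compound 1 `COc1cccc(CNC(=O)c2nc(Br)c3cccnc3c2N[C@H]2CC[C@H](N)CC2)c1`: 7000 nM
- compound 2 `C[C@H](NC(=O)c1nc(Br)c2cccnc2c1N[C@H]1CC[C@H](N)CC1)c1ccc(F)cc1`: > 10000 nM

The entry for compound 2 is a limit of the assay and not a number. Compound 2 stands at the limit of > 10000 nM in this assay, at which 1 of the 2 values shown sits.

The next analogue is compound 3 `N[C@H]1CC[C@H](Nc2c(C(=O)NCc3cccs3)nc(Br)c3cccnc23)CC1`, and the change to it is (thiophen-2-yl)methyl in place of 1-(4-fluorophenyl)ethyl on an amide-type nitrogen. In words, (thiophen-2-yl)methyl takes the place of 1-(4-fluorophenyl)ethyl on an amide-type nitrogen, and the defined stereocentre of the leaving group goes with it.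

Within the data shown here, one measured step bears on this, a change on the same amide-type nitrogen: an at least 1.4-fold higher number from compound 1 to compound 2 (0.15 log units; that floor lies within the scatter). Its floor lies within the scatter, and no true size is known for it. The only numerical anchor in the series is compound 1 at 7000 nM.

Given that step, no change beyond the scatter is expected in this assay, and compound 3 may well return only a limit. The estimated step is an at least 1.2-fold lower number from compound 2 to compound 3 (0.09 log units; that floor lies within the scatter). For compound 3 the estimated value is 8000 nM, with an expected range of 3000 nM to 20000 nM.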

Compound 3, half-maximal inhibitory concentration: 11000 nM
Compound 3: middle estimate off by 1.4-fold (0.14 log units), on the low side; the range from low to high includes it.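

In this assay, compound 3 gives this amide-type nitrogen a second readable number, and the comparison with compound 1 is a 1.6-fold higher number from compound 1 to compound 3 (0.20 log units; within the scatter) on the exchange of 3-methoxyphenyl for thiophen-2-yl. A six-membered aromatic ring of carbon only and a five-membered aromatic ring with 1 hetero atom therefore do not separate at this place, and neither compound 1 nor compound 3 stands apart from the other beyond the scatter. The step from compound 2 to compound 3 cannot be read because compound 2 stands at a limit of the assay and not at a number: the limit of > 10000 nM in this assay, at which 1 of the 3 values shown sits.

On these data alone, whether a carboxylic acid or a longer chain ending in an amine on this nitrogen would move the number beyond the scatter remains open. Also open, as far as these compounds go, is how far compound 2 truly lies from compound 3, and whether the defined stereocentre or the fluorine of 1-(4-fluorophenyl)ethyl has any part in that gap.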